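The source may report more compounds than this note shows. Statements on the series, on what has been measured and on what is new or still open speak of the compounds shown alone.

Measured so far in an ADME assay on microsomes from liver (Mus musculus) for metabolic stability, tested at 5 uM; on this read-out higher numbers stand for a longer-lived compound and lower numbers for a shorter-lived compound:
- compound 1 `CCCCNc1ccc([N+](=O)[O-])cc1S(N)(=O)=O`: 0.1 h
- compound 2 `CN(C)S(=O)(=O)c1cc(C(=O)O)c(Cl)cc1NCCCCCCCC(F)(F)F`: > 1 h
- compound 3 `COc1cc(NCCCCCCCC(F)(F)F)c(S(=O)(=O)N(C)C)cc1C(=O)O`: > 1 h

Compound 2 gives > 1 h, which is a limit and not a number. Compound 3 gives > 1 h, which is also a limit and not a number. Compound 3 therefore sits at the limit of > 1 h in this assay, at which 2 of the 3 values shown sit.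

Compound 4 `CCOc1cc(NCCCCCCCC(F)(F)F)c(S(=O)(=O)N(C)C)cc1C(=O)O` carries methyl in place of hydrogen on a saturated chain carbon bound to an oxygen on an aromatic ring, so methoxy becomes ethoxy. For the measured compounds named here, the one measured step that bears on this is a step that the two limits leave unreadable from compound 2 to compound 3, with methoxy in place of chloro on an aromatic carbon. It offers no readable size to carry over, so in this assay no change beyond the scatter is expected, and no direction is favoured. The estimated step is a step that the limit leaves unreadable from compound 3 to compound 4. Compound 4 is estimated at 1.5 h, with an expected range of 0.6 h to 3 h.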

Compound 4, half-life: > 1 h
Compound 4: only a limit was reported; the forecaster's own chance of this, stated with the estimate: 75%; the middle value lies beyond the limit too.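

In this assay compound 2, compound 3 and compound 4 each give only a limit, so no new step can be read among them. On these data alone, how far apart the true half-lives of these three compounds lie stays open.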